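Swapping Pentyl for tert-Butyl on the Aryl Arm

A few compounds are considered here, and "the series" means these few. Any claim that something is new, unique, unknown or untested is made for them only; others in the source may bear on it.

Compound 1, `Nc1nc(=O)n([C@@H]2O[C@H](CO)[C@@H](O)[C@H](O)[C@H]2O)cc1C#Cc1ccccc1`: in a functional assay on L1210 cells (Mus musculus) for cytotoxicity, with a stated time of 48 h (a higher number here means a weaker inhibitor, a lower number a stronger inhibitor), compound 1 gives >= 250000 nM, which is a limit of the assay rather than a number.
Compound 2, `CCCCCc1ccc(C#Cc2cn([C@@H]3O[C@H](CO)[C@@H](O)[C@H](O)[C@H]3O)c(=O)nc2N)cc1`: in this assay compound 2 gives 132000 nM.

Going by the values given here, compound 2 therefore holds the only real number in this small set; the other value is a limit. Compound 3, `CC(C)(C)c1ccc(C#Cc2cn([C@@H]3O[C@H](CO)[C@@H](O)[C@H](O)[C@H]3O)c(=O)nc2N)cc1`, differs from compound 2 by tert-butyl in place of pentyl on an aromatic carbon. Among the compounds with values here, the only measured step, an at least 1.8-fold lower number from compound 1 to compound 2 (0.27 log units; that floor lies within the scatter), cannot be sized properly because it starts from the limit of >= 250000 nM in this assay, at which 1 of the 2 values shown sits, and it concerns adding an alkyl group rather than exchanging one alkyl for another. Replacing pentyl with tert-butyl keeps an alkyl group of similar bulk on the same aromatic carbon, so no step beyond the usual scatter is expected in this assay. The expected step is a 1.1-fold higher number from compound 2 to compound 3 (0.06 log units; within the scatter), which is within the scatter. Compound 3 is estimated at 150000 nM, with a likely range from 60000 nM to 380000 nM.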

Compound 3, half-maximal inhibitory concentration: > 250000 nM
Compound 3 was reported as a limit; the forecaster's own chance of this, stated with the estimate: 25%; at least 1.6-fold (0.22 log units) between middle value and limit.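

Going by these compounds alone, exchanging pentyl for tert-butyl on the aromatic carbon gives an at least 1.8-fold higher number from compound 2 to compound 3 (0.27 log units; that floor lies within the scatter), the first look at one alkyl group replacing another at this position. Within the data shown here, that figure is only a floor: the true step could be much larger, or it could be no real step at all. The step from compound 1 to compound 3 cannot be read, and compound 3 itself is a limit rather than a number: the limit of > 250000 nM in this assay, at which 1 of the 3 values shown sits.

As far as these compounds go, the true size of the pentyl to tert-butyl step remains open, as no measured number exists for compound 3. Also open, from the compounds shown here alone, is whether a longer chain such as octyl, or an amine or a carboxylic acid at this same place, would move the number of compound 2, 132000 nM, by a clear step.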